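The source may report more compounds than this note shows. Statements on the series, on what has been measured and on what is new or still open speak of the compounds shown alone.

Measured compounds:
- compound 1 `COc1ccc(-c2cc(=O)c3c(OC)cc(OC)cc3n2Cc2ccccc2)cc1` — in a functional assay on HepG2 cells (Homo sapiens) for antiproliferative activity, with a stated time of 72 h (on this read-out lower numbers stand for an effect already at smaller amounts and higher numbers for an effect only at larger amounts of compound), compound 1 gives > 17300 nM, a limit of the assay rather than a number.
- compound 2 `COc1ccc(-c2c(Cl)c(=O)c3c(OC)cc(OC)cc3n2S(=O)(=O)c2ccc(OC)cc2)cc1` — in this assay compound 2 gives "not determined" (no result reported), so no result is reported for it.

Among the compounds with values here, only two compounds have been through this assay, and neither has a plain number. For compound 1 the value reported is a limit, which is the situation described by the limit of > 17300 nM in this assay, at which 1 of the 2 values shown sits. Compound 2 stands without any result at all, so on the numbers shown it has no position: there is nothing to compare it with, and no measured step leads to or from it.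

The unmeasured compound is compound 3 `COc1ccc(-c2c(Br)c(=O)c3c(OC)cc(OC)cc3n2S(=O)(=O)c2ccc(OC)cc2)cc1`. It differs from compound 2 in one place: bromo in place of chloro on an aromatic carbon. Within the data shown here, no pair of measured compounds shows what such a swap does in this assay, so the size and direction of the step cannot be read from the data; a change no larger than the scatter is as plausible as any other.

Among the measured compounds shown here, with the only measured neighbour of this series being a limit, compound 3 is expected to fall around 8000 nM, within a broad range from 1000 nM to 30000 nM, and a limit rather than a number is a real possibility.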

Compound 3, half-maximal effective concentration: > 20000 nM
Compound 3 gave a limit, no number; the forecaster's own chance of this, stated with the estimate: 55%; middle value at least 2.5-fold (0.39 log units) away from the limit.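

No step can be read between compound 2 and compound 3: compound 2 has no reported result in this assay. Compound 3 gives > 20000 nM, which is a limit and not a number. What bromo in place of chloro does on this read-out stays open, as does the size of any effect of these compounds on the cells.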